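This account rests on a few compounds, and the source may have more. Where it says the series, first, only, none or still open, it means among the compounds named here.

Measured in (an ADME assay on MT4 cells (Homo sapiens) for cytotoxicity, read by MTT assay, with a stated time of 5 days; on this read-out higher numbers stand for lower toxicity in this test and lower numbers for higher toxicity in this test):
- Compound 1 (`N#Cc1ccc(Nc2nccc(OCC(=O)Nc3ccc(F)cc3)n2)cc1`) gives (> 344000 nM), a limit.
- Compound 2 (`N#Cc1ccc(Nc2nccc(OCC(=O)Nc3ccc(Cl)cc3)n2)cc1`) gives (162000 nM).
- Compound 3 (`Cc1cc(OCC(=O)Nc2ccc(F)cc2)nc(Nc2ccc(C#N)cc2)n1`) gives (> 331000 nM), a limit.

Compound 3 therefore stands at a limit and not at a number. Compound 4 (`Cc1cc(OCC(=O)Nc2ccc(Cl)cc2)nc(Nc2ccc(C#N)cc2)n1`) differs from it by chloro in place of fluoro on an aromatic carbon, with chloro in place of fluoro on an aromatic carbon, para to a large group. The same exchange was measured once, as (an at least 2.1-fold lower number from compound 1 to compound 2 (0.32 log units; beyond the scatter)), and this step lies beyond the scatter. The methyl step (a step that the two limits leave unreadable from compound 1 to compound 3) gives no size to carry over. A step of similar size and the same direction is thus expected in (this assay), its true size uncertain because it starts from a limit. Compound 4 is estimated at (150000 nM), with an expected range from (70000 nM) to (320000 nM).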

Compound 4, half-maximal cytotoxic concentration: 2630 nM
Compound 4: middle estimate off by 57-fold (1.76 log units), on the high side; the whole stated range lies above it.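

On the methyl-bearing core in this assay, chloro in place of fluoro, para to a large group, gives an at least 120-fold lower number from compound 3 to compound 4 (2.09 log units; beyond the scatter), so this exchange can carry a large step. Methyl in place of hydrogen, which cannot be read in the fluoro pair, can be read in the chloro pair and gives a 62-fold lower number from compound 2 to compound 4 (1.79 log units; beyond the scatter). Its effect in this test is therefore also large, at least with chloro present.

On these data alone, whether the chloro step truly differs between the two cores stays open: the same change on two cores in this assay, an at least 2.1-fold lower number (0.32 log units; beyond the scatter) from compound 1 to compound 2 and an at least 120-fold lower number (2.09 log units; beyond the scatter) from compound 3 to compound 4; the limit leaves it open whether they differ Also open is how bromo in place of chloro, or ethyl in place of methyl, would read.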